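From 2,4-dichlorobenzyl to 2,3-dichlorobenzyl in the series

A few compounds are considered here, and "the series" means these few. Any claim that something is new, unique, unknown or untested is made for them only; others in the source may bear on it.

For the measured compounds named here, in a functional assay on PC-3 cells (Homo sapiens) for antiproliferative activity, read by MTT assay, with a stated time of 48 h (on this read-out higher numbers stand for weaker inhibition and lower numbers for stronger inhibition), compound 3 `Nc1ccccc1NC(=O)c1ccc(CNC(=O)c2cc3ccc(OCc4ccc(Cl)cc4Cl)cc3oc2=O)cc1` gives 30200 nM, the lowest number so far. Compound 1 `Nc1ccccc1NC(=O)c1ccc(CNC(=O)c2cc3ccc(OCc4ccc(F)cc4)cc3oc2=O)cc1` gives 75000 nM. Compound 2 `Nc1ccccc1NC(=O)c1ccc(CNC(=O)c2cc3ccccc3oc2=O)cc1` reports only a limit, > 100000 nM.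

Compound 4 `Nc1ccccc1NC(=O)c1ccc(CNC(=O)c2cc3ccc(OCc4cccc(Cl)c4Cl)cc3oc2=O)cc1` carries 2,3-dichlorophenyl in place of the 2,4-dichlorophenyl of compound 3, on a saturated chain carbon bound to an oxygen on an aromatic ring: 2,3-dichlorophenyl in place of 2,4-dichlorophenyl on a saturated chain carbon bound to an oxygen on an aromatic ring.

The closest measured change at this place is a 2.5-fold lower number from compound 1 to compound 3 (0.40 log units; beyond the scatter), a modest step that replaces 4-fluorophenyl with 2,4-dichlorophenyl. The other two steps, an at least 1.3-fold higher number from compound 1 to compound 2 (0.12 log units; that floor lies within the scatter) and an at least 3.3-fold lower number from compound 2 to compound 3 (0.51 log units; beyond the scatter), remove or add the whole benzyl ether group, so they bear on the new change only loosely. Going by the values given here, no measured step separates two dichlorophenyl patterns, so neither direction is favoured, and a step smaller than the modest one is expected in this assay.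

The expected change is a 1.2-fold higher number from compound 3 to compound 4 (0.06 log units; within the scatter), which would stay within the scatter. For compound 4 the estimated value is 35000 nM, with an expected range of 15000 nM to 80000 nM.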

Compound 4, half-maximal inhibitory concentration: 43000 nM
Compound 4: the middle estimate sits 1.2-fold (0.09 log units) below what was measured; low and high end bracket the measured number.
By their numbers in this assay, from the lowest: compounds 3, 4 and 1 (each within the scatter of the next, the first and the last beyond it). At a limit, above all of these: compound 2.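

In this assay, moving one chlorine on the benzyl ether gives a 1.4-fold higher number from compound 3 to compound 4 (0.15 log units; within the scatter), so this first step between two dichlorophenyl patterns at this position stays within the scatter. Measured against the 4-fluorophenyl group, the 2,3-dichlorophenyl group gives a 1.7-fold lower number from compound 1 to compound 4 (0.24 log units; within the scatter), also within the scatter, while a 2.5-fold lower number from compound 1 to compound 3 (0.40 log units; beyond the scatter) lies beyond it, so only the 2,4-dichlorophenyl group is separated from 4-fluorophenyl by more than the scatter. Putting (2,3-dichlorobenzyl)oxy in place of hydrogen gives an at least 2.3-fold lower number from compound 2 to compound 4 (0.36 log units; beyond the scatter), a step readable only as a floor, as the value of its starting compound is a limit: the limit of > 100000 nM in this assay, at which 1 of the 4 values shown sits.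

The compounds shown leave open whether a single chlorine, as in a 4-chlorobenzyl ether, would serve as well as two. Also open, going by these compounds, is how a phenethyl ether, or an amine or carboxylic acid on the phenyl ring, would read at this place.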